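Rat clearance notes: bromo in place of methyl

The source may hold more compounds than are shown below. What is called first, only, known or untested is meant among the compounds shown, and "the series" means these compounds.

- compound 1 `Clc1cncc(OC2C=C(C#Cc3ccccn3)CCC2)c1`: 32 mL/min/kg
- compound 2 `Cc1ccc(S(=O)(=O)N2CC=C(C#Cc3ccccn3)CC2)cc1`: 29 mL/min/kg

In an in vivo ADME assay on the whole organism (Rattus norvegicus) for pharmacokinetics, at a dose of 2 mg/kg by the intravenous route (on this read-out higher numbers stand for fast clearance and lower numbers for slow clearance), compound 2 gives 29 mL/min/kg. This value and that of compound 1 lie within the scatter of each other, so the two measurements do not separate the compounds. Both values fall in one narrow band, but two compounds are too few to support a pattern.

The next compound to be measured is compound 3 `O=S(=O)(c1ccc(Br)cc1)N1CC=C(C#Cc2ccccn2)CC1`. It keeps the rest of compound 2 and carries bromo in place of methyl on an aromatic carbon, para to a large group, which reads as 4-methylphenyl to 4-bromophenyl: bromo in place of methyl on an aromatic carbon. Among the compounds with values here, no measured pair shows this change, so its effect on clearance has no direct precedent here. Within the data shown here, the only anchor is compound 2 at 29 mL/min/kg.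

With no evidence for a direction, no change beyond the scatter is expected. The expected size of the step of a 1.1-fold lower number from compound 2 to compound 3 (0.05 log units; within the scatter) is small, and its direction is uncertain. For compound 3 the estimated clearance in this assay is 26 mL/min/kg, with an expected range of 14 mL/min/kg to 48 mL/min/kg.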

Compound 3, clearance: 64 mL/min/kg
For compound 3 the middle estimate is 2.5-fold (0.39 log units) below the measured one, outside the stated range (above it).
By their numbers in this assay, from the lowest: compounds 2, 1 and 3 (each within the scatter of the next, the first and the last beyond it).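

In this assay, within the data shown here, the change from 4-methylphenyl to 4-bromophenyl gives a 2.2-fold higher number from compound 2 to compound 3 (0.34 log units; beyond the scatter), the first single-place comparison, and it shows that clearance responds to what sits at this place on the aromatic carbon, para to a large group. The exchange is small on paper: one heavy atom leaves, one heavy atom enters, and no ring, hydrogen-bond donor, hydrogen-bond acceptor or net charge comes or goes, so a modest shift in clearance does not need a larger change in the counted features. No supporting data at hand bear on the origin of this step.

From the compounds shown here alone, one pair gives one direction for one exchange on one core, so it remains open whether other groups at this place, such as fluoro, methoxy, nitrile or a carboxylic acid, would track with methyl or with bromo. Also open, going by these compounds, is whether the same exchange would give a step of similar size on a different core, including that of compound 1.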